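From compound 3 to compound 4: removing one ring group

The compounds below may be only part of what the source reports. "The series", "measured", "known", "first", "only" and "open" are said of these compounds alone.

Of the compounds shown here, three sharing one core have been measured so far. In a functional assay, with a stated time of 60 min, in the absence of a further agent (on this read-out lower numbers stand for stronger inhibition and higher numbers for weaker inhibition), compound 1 `COc1cc2c(cc1O)CCC(C)(CC(=O)O)O2` gives 8400 nM, and compound 2 `COc1cc2c(cc1O)CCC(C)(CC(N)=O)O2` gives 10500 nM. Compound 3 `COc1cc2c(cc1O)CCC(C)(CCNC(=O)C[C@H]1OC(O)[C@H](O)[C@@H](O)[C@@H]1O)O2` gives 13100 nM, a number within the usual scatter of repeated measurements of both others, so the three cannot be ranked.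

The unmeasured compound 4 `COc1cc2c(cc1O)CCC(C)(CCNC(C)=O)O2` comes from compound 3 through a single change: hydrogen in place of 3,4,5,6-tetrahydroxyoxan-2-yl on a saturated chain carbon bound to a carbonyl carbon. That is, hydrogen in place of 3,4,5,6-tetrahydroxyoxan-2-yl on a saturated chain carbon bound to a carbonyl carbon.

For the measured compounds named here, no measured pair tests this change directly. Going by the values given here, the only single-place step available is a 1.3-fold higher number from compound 1 to compound 2 (0.10 log units; within the scatter), with amino in place of hydroxy on a carbonyl carbon, and it is a small step within the scatter. Compound 2 also lacks the 3,4,5,6-tetrahydroxyoxan-2-yl group, and its 10500 nM lies within the scatter of compound 3. This indirect evidence leads to the expectation of no change beyond the scatter in this assay. The expected step is a 1.2-fold lower number from compound 3 to compound 4 (0.08 log units; within the scatter). The estimate for compound 4 is 11000 nM, with an expected range from 6000 nM to 20000 nM.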

Compound 4, half-maximal inhibitory concentration: 14300 nM
Compound 4: the middle estimate sits 1.3-fold (0.11 log units) below what was measured; low and high end bracket the measured number.
By their numbers in this assay, from the lowest: compounds 1, 2, 3 and 4 (each within the scatter of the next).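

In this assay, the direct test of this change, hydrogen in place of 3,4,5,6-tetrahydroxyoxan-2-yl on a saturated chain carbon bound to a carbonyl carbon, gives a 1.1-fold higher number from compound 3 to compound 4 (0.04 log units; within the scatter). A ring of 10 heavy atoms with 4 defined stereocentres can therefore be removed from this place without a difference that can be told from the scatter. The other two comparisons concern a saturated chain carbon bound to a saturated ring carbon: acetamidomethyl in place of carbamoyl gives a 1.4-fold higher number from compound 2 to compound 4 (0.13 log units; within the scatter), and acetamidomethyl in place of carboxy gives a 1.7-fold higher number from compound 1 to compound 4 (0.23 log units; within the scatter), so these three groups cannot be told apart here, and nothing on hand explains why the numbers stay so close.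

Going by these compounds, all four compounds lie within the scatter of their neighbours, so it remains open whether any group at this place can move the number at all, for example a primary amine or a longer alkyl chain in place of acetamidomethyl. On these data alone, all four also carry the same hydroxy and methoxy groups on the shared core, so the effect of replacing either of those groups remains unknown.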